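The source may hold more compounds than are shown below. What is called first, only, known or untested is meant among the compounds shown, and "the series" means these compounds.

Measured compounds:
compound 1 `O=C(C1CCCCC1)N1CC(c2nc(-c3cccc(F)c3)no2)C1` — 1000 nM
compound 3 `O=C(C1CCC(C(F)(F)F)CC1)N1CC(c2nc(-c3cccc(F)c3)no2)C1` — 680 nM
compound 2 `Cc1ccc(S(=O)(=O)N2CC(c3nc(-c4cccc(Cl)c4)no3)C2)cc1` — > 10000 nM, which is a limit of the assay and not a number the limit of > 10000 nM in this assay, at which 1 of the 3 values shown sits.

In an assay on HEK293 cells for positive allosteric modulation of metabotropic glutamate receptor 5 (Homo sapiens), read by FLIPR (a lower number here means that less compound is needed, a higher number that more compound is needed for the effect), compound 1 has the higher of the two numbers, but its nearest neighbour is compound 3, and the step of a 1.5-fold lower number from compound 1 to compound 3 (0.17 log units; within the scatter) lies within the scatter, so the two cannot be ordered. Compound 2 gives only a limit.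

Compound 4 `O=C(c1ccc(F)cc1)N1CC(c2nc(-c3cccc(F)c3)no2)C1` differs from compound 1 in one place: 4-fluorophenyl in place of cyclohexyl on a carbonyl carbon. Going by the values given here, no measured step touches the group on the carbonyl carbon; the single measured step, a 1.5-fold lower number from compound 1 to compound 3 (0.17 log units; within the scatter), changes the saturated ring elsewhere and stays within the scatter. Compound 2 carries an aromatic ring on a sulfonyl group rather than a carbonyl and gives a limit, so it gives no direction either. With nothing to point one way, no step beyond the scatter is expected, and the estimated step of no change at the digits printed from compound 1 to compound 4 (within the scatter) is set near zero with a wide range. Compound 4 is therefore expected at about 1000 nM, between 300 nM and 3500 nM in this assay.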

Compound 4, half-maximal effective concentration: 2400 nM
Compound 4: middle estimate off by 2.4-fold (0.38 log units), on the low side; the range from low to high includes it.
By their numbers in this assay, from the lowest: compounds 3 and 1 (each within the scatter of the next); then compound 4. At a limit, above all of these: compound 2.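

Going by these compounds alone, the group on the carbonyl carbon is the first place where a single change moves the number in this assay beyond the scatter: a 2.4-fold higher number from compound 1 to compound 4 (0.38 log units; beyond the scatter). This position therefore responds to the exchange of cyclohexyl for 4-fluorophenyl, although the step is modest and compound 4 still gives a measured number rather than a limit. Nothing measured here accounts for this step.

On these data alone, whether the step comes from the aromatic ring itself or from its fluorine remains open, and an unsubstituted phenyl on the carbonyl carbon would separate the two. Also open, as far as these compounds go, is how a longer chain, or a ring carrying an amine, would behave at this position relative to compound 1.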